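The compounds below may be only part of what the source reports. "The series", "measured", "known", "first", "only" and "open" are said of these compounds alone.

Compounds measured in a functional assay on MRC5 cells (Homo sapiens) for inhibition, read by microscopy and resazurin assay, with a stated time of 72 h; a higher number here means a weaker inhibitor, a lower number a stronger inhibitor:

Compound 1 `C=CCONC(=O)Cn1cc(C(=O)NCC(=O)N[C@H](C(=O)O)C(C)C)c2ccccc21` gives > 128000 nM, which is a limit of the assay.
Compound 2 `C=CCONC(=O)Cn1ccc(C(=O)N[C@@H](C)C(=O)N[C@H](C(=O)O)C(C)C)c1` gives > 128000 nM, again a limit.
Compound 3 `C=CCONC(=O)Cn1ccc(C(=O)N[C@@H](C)C(=O)N[C@@H](CC(C)C)C(=O)O)c1` gives > 128000 nM, also a limit.

Going by the values given here, compound 3 therefore has no number of its own in this assay; it sits at the same limit as the other two, and no step among them can be read. Among the compounds with values here, the one step computed among the measured compounds, a step that the two limits leave unreadable from compound 2 to compound 3, stays unreadable for this reason. Compound 4 `CC(C)C[C@H](NC(=O)[C@H](C)NC(=O)c1ccn(CC(=O)NOCc2ccccc2)c1)C(=O)O` differs from compound 3 in a single place: phenyl in place of vinyl on a saturated chain carbon bound to an oxygen on an unsaturated carbon. Within the data shown here, nothing among the measured steps bears on this change, since all three compounds share the allyloxy group and all three sit at the limit, as summarised by the limit of > 128000 nM in this assay, at which 3 of the 3 values shown sit. The closest information is that the backbone common to compound 3 and compound 4 has shown no measurable inhibition in any of its three tested forms. The expectation for compound 4 is thus that this assay will most likely again report only a limit rather than a number, with the step of a number no higher from compound 3 to compound 4 (the limit leaves the size open) estimated at nothing beyond the scatter. If a number is obtained, compound 4 is estimated at 128000 nM, within 40000 nM to 400000 nM.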

Compound 4, half-maximal inhibitory concentration: > 128000 nM
Compound 4 ended at the assay's limit; the forecaster's own chance of this, stated with the estimate: 85%; the middle value lies on the limit itself.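

No step can be read from compound 3 to compound 4, because both stand at a limit and not at a number in this assay: the limit of > 128000 nM in this assay, at which 4 of the 4 values shown sit.

The compounds shown leave open whether benzyloxy in place of allyloxy changes inhibition at all, and what number any of these compounds would give.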